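Cyano in place of methoxycarbonyl: a step expected to stay flat

A few compounds are considered here, and "the series" means these few. Any claim that something is new, unique, unknown or untested is made for them only; others in the source may bear on it.

Compound 1 `O=C(O)CC(Cc1nc2cc(Cl)ccc2[nH]1)c1ccc(Cl)cc1`
Compound 2 `COc1ccc2[nH]c(CC(CC(=O)O)c3ccc(Cl)cc3)nc2c1`
Compound 3 `COC(=O)c1ccc2[nH]c(CC(CC(=O)O)c3ccc(Cl)cc3)nc2c1`

In an assay on isolated protein for inhibition of protein kinase C zeta type (Homo sapiens), read by 33P incorporation, tested at 50 uM (a lower number here means a weaker effect, a higher number a stronger effect of the compound at the concentration tested), compound 1 gives 0%, compound 2 gives 0% and compound 3 gives 0%. Compound 3 therefore stands level with the other two, with nothing measured here beyond the scatter. The next compound, compound 4 `N#Cc1ccc2[nH]c(CC(CC(=O)O)c3ccc(Cl)cc3)nc2c1`, carries a single change on the shared core: cyano in place of methoxycarbonyl on an aromatic carbon. For the measured compounds named here, three measured steps bear on it, all swaps on the same aromatic carbon, and each was flat: no change at the digits printed from compound 1 to compound 2 (within the scatter), no change at the digits printed from compound 1 to compound 3 (within the scatter) and no change at the digits printed from compound 2 to compound 3 (within the scatter). Since every variation at this position has so far left the read-out unchanged, the expected step of no change at the digits printed from compound 3 to compound 4 (within the scatter) is none beyond the scatter. Compound 4 is thus estimated at 0%, within a range from -8% to 10%.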

Compound 4, a percentage reported as inhibition, at one concentration (the size of the read-out at that concentration, not a potency): 0%
For compound 4 middle estimate and measured number coincide at the digits printed; the range from low to high includes it.
By their numbers in this assay, from the lowest: compounds 1, 2, 3 and 4 (each within the scatter of the next).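

In this assay, cyano in place of methoxycarbonyl gives no change at the digits printed from compound 3 to compound 4 (within the scatter) and cyano in place of methoxy gives no change at the digits printed from compound 2 to compound 4 (within the scatter) while cyano in place of chloro gives no change at the digits printed from compound 1 to compound 4 (within the scatter) as well. Cyano, with its triple bond, thus joins chloro, methoxy and methoxycarbonyl as a fourth group on this aromatic carbon that leaves the read-out where it was. Nothing measured here explains this flatness.

From the compounds shown here alone, whether an amine, a carboxylic acid or a longer chain on this carbon would move the read-out stays open. So does whether a change elsewhere on the shared core would lift it above the level all four compounds share.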